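Series notes: chloro for the aminoalkylamino substituent

This account rests on a few compounds, and the source may have more. Where it says the series, first, only, none or still open, it means among the compounds named here.

The series shares one core. Compound 3 `C=CCOc1ccc2c(NCCN(C)C)ccnc2c1` gives 1560 nM in a functional assay on SK-OV-3 cells (Homo sapiens) for cytotoxicity, read by MTT assay, with a stated time of 48 h; on this read-out higher numbers stand for weaker inhibition and lower numbers for stronger inhibition. Compound 1 `CC(C)COc1ccc2c(Cl)ccnc2c1` gives 3190 nM, and compound 2 `Clc1ccnc2cc(OCc3ccccc3)ccc12` gives 5170 nM, so compound 3 holds the lowest number of the three, with its gaps to compound 1 and to compound 2 both beyond the scatter. For the measured compounds named here, the one step measured within one change, a 1.6-fold higher number from compound 1 to compound 2 (0.21 log units; within the scatter), concerns the ether substituent and is within the scatter.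

Compound 4 `C=CCOc1ccc2c(Cl)ccnc2c1` differs from compound 3 in one place: chloro in place of (2-(dimethylamino)ethyl)amino on an aromatic carbon. Going by the values given here, no measured step covers this exact change. Compound 4 shares the chloro group with compound 1 and differs from it only in the ether substituent, and the ether change seen in a 1.6-fold higher number from compound 1 to compound 2 (0.21 log units; within the scatter) moved little. Compound 4 is therefore expected to land near compound 1, which gives 3190 nM, giving an expected step of a 1.9-fold higher number from compound 3 to compound 4 (0.28 log units; within the scatter) toward a higher number. The estimate for compound 4 is 3000 nM, with a range from 1200 nM to 7500 nM.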

Compound 4, half-maximal inhibitory concentration: 4030 nM
Estimate against measurement, compound 4: 1.3-fold (0.13 log units) below; the range from low to high includes it.
By their numbers in this assay, from the lowest: compound 3; then compounds 1, 4 and 2 (each within the scatter of the next).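

Chloro in place of (2-(dimethylamino)ethyl)amino, on the aromatic carbon opposite the ring nitrogen, gives the first measured step at this position in this assay (a 2.6-fold higher number from compound 3 to compound 4 (0.41 log units; beyond the scatter)), and with the ether substituent unchanged, the aminoalkylamino compound carries the lower number. The three chloro compounds show no separation by ether substituent (a 1.3-fold higher number from compound 1 to compound 4 (0.10 log units; within the scatter); a 1.3-fold lower number from compound 2 to compound 4 (0.11 log units; within the scatter)), so vinyl now joins isopropyl and phenyl on the chain carbon bound to the oxygen, all within the scatter. Nothing available here explains the step at this position.

Going by these compounds, whether a longer aminoalkylamino chain, or a piperazine on the same carbon, would take the number lower stays open. On these data alone, only compound 3 carries (2-(dimethylamino)ethyl)amino, and whether the ether substituent stays as flat with that group in place is also open.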